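A few compounds are considered here, and "the series" means these few. Any claim that something is new, unique, unknown or untested is made for them only; others in the source may bear on it.

Measured so far in a functional assay on VCaP cells (Homo sapiens) for antiproliferative activity, read by propidium iodide staining, with a stated time of 96 h; a higher number here means a weaker inhibitor, a lower number a stronger inhibitor:
- compound 1 `CC(O)(COc1ccc(S(F)(F)(F)(F)F)cc1)C(=O)Nc1ccc([N+](=O)[O-])c(C(F)(F)F)c1`: 100000 nM
- compound 2 `CC(O)(CS(=O)(=O)c1ccc(S(F)(F)(F)(F)F)cc1)C(=O)Nc1ccc([N+](=O)[O-])cc1C(F)(F)F`: 28600 nM
- compound 3 `CC(O)(CS(=O)(=O)c1ccc(S(F)(F)(F)(F)F)cc1)C(=O)Nc1ccc(S(F)(F)(F)(F)F)cc1`: 15700 nM

Compound 3 and compound 2 lie within the scatter of each other, while the number for compound 1 is higher than that for compound 3 by more than the scatter. Compound 4 `CC(O)(CS(=O)(=O)c1ccc(F)cc1)C(=O)Nc1ccc(S(F)(F)(F)(F)F)cc1` departs from compound 3 in one place: one fluorine atom in place of a group of 6 heavy atoms (5 fluorine, 1 sulfur; no ring), on an aromatic carbon on an aromatic carbon of a six-membered aromatic ring of carbon only, para to a large group. For the measured compounds named here, no measured pair isolates this change, so no step beyond the scatter is expected in this assay from the data at hand. The expectation starts from compound 3 at 15700 nM and stays close to it. The estimate implies a 1.3-fold higher number from compound 3 to compound 4 (0.11 log units; within the scatter) as the expected step. For compound 4 the estimated value is 20000 nM with an expected range from 7000 nM to 60000 nM in this measurement.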

Compound 4, half-maximal inhibitory concentration: 34200 nM
The estimate for compound 4 lay 1.7-fold (0.23 log units) below the measured number; measured number inside the range.
By their numbers in this assay, from the lowest: compounds 3, 2 and 4 (each within the scatter of the next, the first and the last beyond it); then compound 1.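

In this assay, for the compounds shown here, replacing the group of 6 heavy atoms (5 fluorine, 1 sulfur) with one fluorine atom on this aromatic carbon gives a 2.2-fold higher number from compound 3 to compound 4 (0.34 log units; beyond the scatter) as the first step that can be read at this place. This modest step shows that the number responds to what this carbon carries, with the larger group giving the lower number in this single pair. Nothing available explains the step. As far as these compounds go, whether a chlorine atom, a methoxy group or a nitrile here would track compound 3 or compound 4 remains open. So does whether the step would hold on the core of compound 2.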